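Phenyl to 4-chlorophenyl on the shared core

A few compounds are considered here, and "the series" means these few. Any claim that something is new, unique, unknown or untested is made for them only; others in the source may bear on it.

Measured so far:
compound 1, `COc1cc2c(Oc3ccc(NC(=O)N/N=C/c4ccncc4)cc3F)ccnc2cc1OCCCN1CCCCC1`: 1400 nM in a functional assay on MDA-MB-231 cells (Homo sapiens) for cytotoxicity, read by MTT assay, with a stated time of 72 h; a higher number here means a weaker inhibitor, a lower number a stronger inhibitor
compound 2, `COc1cc2c(Oc3ccc(NC(=S)N/N=C/c4ccccc4)cc3F)ccnc2cc1OCCCN1CCCCC1`: 1200 nM in this assay

Among the compounds with values here, only two numbers exist in this assay. Compound 2 and compound 1 are separated by a 1.2-fold lower number from compound 1 to compound 2 (0.07 log units; within the scatter), so neither can be called the stronger inhibitor; compound 2 merely has the number at the lower end of the two.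

Compound 3, `COc1cc2c(Oc3ccc(NC(=S)N/N=C/c4ccc(Cl)cc4)cc3F)ccnc2cc1OCCCN1CCCCC1`, is not yet measured. It differs from compound 2 by chloro in place of hydrogen on an aromatic carbon. Within the data shown here, the one measured step, from compound 1 to compound 2, exchanged an arm of the molecule rather than adding a substituent to the phenyl, and it moved the number only within the scatter. Among the measured compounds shown here, no measured step touches the phenyl itself, so the data give no basis for a directed expectation in this assay; the default expectation is a step of no more than the scatter, in either direction.

Compound 3 is therefore estimated at 1000 nM in this assay, with a range of 400 nM to 2500 nM, an expected step of a 1.2-fold lower number from compound 2 to compound 3 (0.08 log units; within the scatter).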

Compound 3, half-maximal inhibitory concentration: 1300 nM
Estimate against measurement, compound 3: 1.3-fold (0.11 log units) below; the measured number falls inside the stated range.
By their numbers in this assay, from the lowest: compounds 2, 3 and 1 (each within the scatter of the next).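

In this assay, within the data shown here, placing chloro in place of hydrogen on the aromatic carbon para to a large group gives a 1.1-fold higher number from compound 2 to compound 3 (0.03 log units; within the scatter) and so produces no readable change: this is the first measured substitution on the phenyl itself, and at this position the added chlorine atom leaves the number within the scatter of compound 2. The wider exchange that replaces the whole arm and also carries the chloro gives a 1.1-fold lower number from compound 1 to compound 3 (0.03 log units; within the scatter) and likewise stays within the scatter, so the three compounds fall into no order in this assay. No measurement available here bears on this result.

Still open, going by these compounds, is whether this position stays as flat with groups other than chloro, such as an amine, a carboxylic acid or a methoxy group, and whether the same holds for chloro elsewhere on the phenyl. Also open, on these data alone, is what the carbonyl and thiocarbonyl arms do on their own with the same ring attached, as compound 1 and compound 2 differ in that ring as well as in that atom.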